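Trifluoromethyl for Chloro on the Urea Tail

The compounds below may be only part of what the source reports. "The series", "measured", "known", "first", "only" and "open" are said of these compounds alone.

The three measured compounds share one urea core. Compound 1 `Cc1ccc(NC(=O)Nc2cc(C)nc3ccccc23)cc1` was tested in an ADME assay on HepG2 cells (Homo sapiens) for cytotoxicity, with a stated time of 72 h; a higher number here means that more compound is needed for the effect, a lower number that less compound is needed. In this assay compound 1 reaches only a limit of the assay, > 25000 nM. Compound 2 `COC(=O)c1ccc(NC(=O)Nc2cc(C)nc3ccccc23)cc1` carries methoxycarbonyl where compound 1 carries methyl, and in this assay compound 2 gives 20000 nM. Compound 3 `Cc1cc(NC(=O)Nc2ccc(Cl)cc2)c2ccccc2n1` carries chloro at that same aromatic carbon. In this assay compound 3 is reported only as a limit, > 25000 nM. Compound 3 therefore stands at the top of what the assay can report, as the limit of > 25000 nM in this assay, at which 2 of the 3 values shown sit, records, and no number is known for it. The measured steps are all small or unreadable: an at least 1.2-fold lower number from compound 1 to compound 2 (0.09 log units; that floor lies within the scatter), an at least 1.2-fold higher number from compound 2 to compound 3 (0.09 log units; that floor lies within the scatter), and a step that the two limits leave unreadable from compound 1 to compound 3.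

Compound 4 `Cc1cc(NC(=O)Nc2ccc(C(F)(F)F)cc2)c2ccccc2n1` differs from compound 3 in one place: trifluoromethyl in place of chloro on an aromatic carbon. All measured steps swap groups on that aromatic carbon, and none of them moves the number beyond the scatter, so no step beyond the scatter is expected in this assay either. Compound 4 is therefore expected to give 30000 nM, within 12000 nM to 80000 nM, and most likely to be reported again as a limit. The expected step is a step that the limit leaves unreadable from compound 3 to compound 4.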

Compound 4, half-maximal effective concentration: 23000 nM
Compound 4: the middle estimate sits 1.3-fold (0.12 log units) above what was measured, and the stated range covers the measured number.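

In this assay, trifluoromethyl gives this aromatic carbon, para to a large group, its first comparison with a number at both ends: a 1.2-fold higher number from compound 2 to compound 4 (0.06 log units; within the scatter). Against the two compounds held at a limit of the assay, the change yields only floors, an at least 1.0-fold lower number from compound 3 to compound 4 (0.03 log units; that floor lies within the scatter) and an at least 1.0-fold lower number from compound 1 to compound 4 (0.03 log units; that floor lies within the scatter), and neither floor shows how large the true step is. Compound 1 and compound 3 therefore still mark only where the assay stops reporting, and the steps that join them to each other cannot be read: the limit of > 25000 nM in this assay, at which 2 of the 4 values shown sit.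

The compounds shown leave open whether a group of another kind on this aromatic carbon, such as an amine or a carboxylic acid, would move the number beyond the scatter, as no readable step among methyl, methoxycarbonyl, chloro and trifluoromethyl does. They also leave open whether a change elsewhere on the shared core, such as a longer chain in place of its methyl, would shift the number in this assay.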